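Oxan-2-yl in Place of Pyrrolidin-2-yl Beside the Sulfonyl

A few compounds are considered here, and "the series" means these few. Any claim that something is new, unique, unknown or untested is made for them only; others in the source may bear on it.

Of the compounds shown here, three sharing one core have been measured. In a functional assay, read by fluorescence and spectrophotometry, with a stated time of 1 h (a lower number here means that less compound is needed, a higher number that more compound is needed for the effect), compound 1 `CCCCCCCCCCCCS(=O)(=O)/C=C/c1ccc(O)c(O)c1` gives 8500 nM. Compound 2 `O=S(=O)(/C=C/c1ccc(O)c(O)c1)CC1CCCN1` gives 13800 nM in this assay, and compound 3 `O=S(=O)(/C=C/c1ccc(O)c(O)c1)CCCCCCCCCCCO` gives 22600 nM there. Compound 2 thus holds the second highest of the three numbers; it sits within the scatter of compound 1 on one side and of compound 3 on the other. Going by the values given here, the only step between compounds differing in one place is a 2.7-fold higher number from compound 1 to compound 3 (0.42 log units; beyond the scatter), a change far out on the chain.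

Compound 4 `O=S(=O)(/C=C/c1ccc(O)c(O)c1)CC1CCCCO1` differs from compound 2 by oxan-2-yl in place of pyrrolidin-2-yl on a saturated chain carbon bound to a sulfonyl sulfur. Among the compounds with values here, no measured step touches the saturated chain carbon bound to a sulfonyl sulfur, so the one step that exists, between compound 1 and compound 3, bears only loosely on it, and it was modest. Across the three measured compounds the numbers all fall within a narrow band. Compound 4 is therefore expected to give about 14000 nM, with a range from 5000 nM to 40000 nM. That estimate means a step of a 1.0-fold higher number from compound 2 to compound 4 (0.01 log units; within the scatter), expected to stay within the scatter.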

Compound 4, half-maximal effective concentration: 10800 nM
The estimate for compound 4 lay 1.3-fold (0.11 log units) above the measured number; measured number inside the range.
By their numbers in this assay, from the lowest: compounds 1, 4, 2 and 3 (each within the scatter of the next, the first and the last beyond it).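

Going by these compounds alone, this is the first step that touches the saturated chain carbon bound to a sulfonyl sulfur: in this assay, oxan-2-yl in place of pyrrolidin-2-yl gives a 1.3-fold lower number from compound 2 to compound 4 (0.11 log units; within the scatter). The change replaces a five-membered non-aromatic ring carrying 1 hydrogen-bond donor with a six-membered one carrying 0 hydrogen-bond donors, and for this pair that difference does not separate the two numbers beyond the usual scatter of the assay. Nothing at hand explains why the two compounds read alike.

This one pair changes ring size and hetero atom together, so it cannot show how either change would read alone; piperidin-2-yl or oxolan-2-yl at the same place would pull the two apart. It also leaves open whether the same place would tolerate groups further from these two rings, such as a carboxylic acid or an open-chain amine, which could show whether the numbers stay within the scatter there or move beyond it.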